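Swapping a Triazole for Chlorine on the Outer Ring

A few compounds are considered here, and "the series" means these few. Any claim that something is new, unique, unknown or untested is made for them only; others in the source may bear on it.

Compound 1 `C(=C1\CCCN=C1c1cccnc1)\c1ccc(-n2ccnn2)cc1` carries a 1H-1,2,3-triazol-1-yl group on its outer benzene ring. In an assay on membranes from brain for displacement of a labelled ligand from Neuronal acetylcholine receptor; alpha4/beta2 (Rattus norvegicus), with a stated time of 3 h (a lower number here means a stronger inhibitor, a higher number a weaker inhibitor), compound 1 gives 520 nM, the higher of the two numbers measured and so the weaker binder of the pair. Compound 2 `COc1ccc(/C=C2\CCCN=C2c2cccnc2)c(OC)c1`, which bears two methoxy groups instead, gives 250 nM in this assay, a gap beyond the usual scatter.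

Compound 3 `Clc1ccc(/C=C2\CCCN=C2c2cccnc2)cc1` differs from compound 1 in one place: chloro in place of 1H-1,2,3-triazol-1-yl on an aromatic carbon. A five-membered aromatic ring with 3 hetero atoms leaves and a single chlorine atom enters, on an aromatic carbon of the six-membered ring of carbon only, para to a large group. Within the data shown here, no measured pair shows this exchange, so the expectation rests on the two values alone. The step of a 1.5-fold lower number from compound 1 to compound 3 (0.17 log units; within the scatter) is expected to be small, toward a slightly lower number, and within the scatter. Compound 3 is therefore estimated at 350 nM, with a range from 120 nM to 1000 nM.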

Compound 3, inhibition constant: 970 nM
For compound 3 the middle estimate is 2.8-fold (0.44 log units) below the measured one; the measured number falls inside the stated range.
By their numbers in this assay, from the lowest: compound 2; then compounds 1 and 3 (each within the scatter of the next).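

In this assay, the exchange of 1H-1,2,3-triazol-1-yl for chloro gives a 1.9-fold higher number from compound 1 to compound 3 (0.27 log units; within the scatter). On this aromatic carbon, para to a large group, a five-membered aromatic ring with 3 hydrogen-bond acceptors can therefore give way to a single chlorine atom with 0 acceptors, and the two numbers remain within the scatter of each other. Nothing measured here explains why two such different groups read so alike.

This single pair cannot show whether the same holds for other groups at this place, such as an amine or a carboxylic acid. It also leaves open whether chloro and 1H-1,2,3-triazol-1-yl would read as closely at any other carbon of the outer ring.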